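The compounds below may be only part of what the source reports. "The series", "measured", "known", "first", "only" and "open" are said of these compounds alone.

Compounds measured in a functional assay on HepG2 cells (Homo sapiens) for cytotoxicity, read by MTT assay, with a stated time of 72 h; on this read-out lower numbers stand for stronger inhibition and higher numbers for weaker inhibition:
compound 1 `COc1ccc(-n2ccc(=O)c(C(=O)Nc3ccc(Oc4ccnc5[nH]ccc45)c(F)c3)n2)cc1` — > 60000 nM
compound 2 `O=C(Nc1ccc(Oc2ccnc3[nH]ccc23)c(F)c1)c1nn(-c2ccc(Br)cc2)ccc1=O` — 68000 nM
compound 3 `COc1ccc(-n2ccc(=O)c(C(=O)Nc3ccc(Oc4ccnc5c4ccn5C)cc3)n2)cc1` — > 60000 nM

Compound 1 returns only a limit in this assay, > 60000 nM. Compound 2 gives 68000 nM in this assay. The change between them is bromo in place of methoxy on an aromatic carbon, and the step that the limit leaves unreadable from compound 1 to compound 2 cannot be read as a number. Compound 3 also returns only a limit in this assay, > 60000 nM. How the core of compound 3 differs from that of compound 1 is not broken down here. Compound 4 `Cn1ccc2c(Oc3ccc(NC(=O)c4nn(-c5ccc(Br)cc5)ccc4=O)cc3)ccnc21` carries the same change as compound 2 did, (bromo in place of methoxy on an aromatic carbon), and has yet to be measured in this assay. Since the limit of > 60000 nM in this assay, at which 2 of the 3 values shown sit, holds two of the three values, the earlier step gives no readable size, so the step that the limit leaves unreadable from compound 3 to compound 4 is expected to be small. Compound 4 is therefore estimated at 70000 nM, between 40000 nM and 150000 nM.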

Compound 4, half-maximal inhibitory concentration: 39200 nM
Compound 4: the middle estimate sits 1.8-fold (0.25 log units) above what was measured; the whole stated range lies above it.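

In this assay, bromo in place of methoxy on the core of compound 3 gives an at least 1.5-fold lower number from compound 3 to compound 4 (0.18 log units; that floor lies within the scatter), so this floor alone does not establish a real difference. On these data alone, compound 3 returns only a limit, > 60000 nM, so the true size of the step remains unknown. The step for the same change on the core of compound 1 cannot be read either, and whether the change carries from one core to the other with a similar size stays undecided because of where the values sit: the limit of > 60000 nM in this assay, at which 2 of the 4 values shown sit.

The compounds shown carry only methoxy or bromo at this place on the phenyl ring. As far as these compounds go, how an amine or a carboxylic acid there would read remains open.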